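Working notes: cyclohexylmethyl arm replaced by 4-aminobenzyl

This account rests on a few compounds, and the source may have more. Where it says the series, first, only, none or still open, it means among the compounds named here.

Measured so far in an assay on cell membranes for binding affinity to adenosine receptor A1 (Bos taurus), read by radioligand binding; on this read-out lower numbers stand for stronger inhibition and higher numbers for weaker inhibition:
compound 1 `c1ccc(Cn2nnc3c(NCC4CCCCC4)ncnc32)cc1` gives 2790 nM
compound 2 `Clc1ccccc1Cn1nnc2c(NCC3CCCCC3)ncnc21` gives 4260 nM
compound 3 `Clc1cccc(Nc2ncnc3c2nnn3Cc2ccccc2)c1` gives 463 nM

Compound 2 carries the highest number of the three in this assay. Compound 1 sits within the scatter of it, so the two are not separable; compound 3 stands clearly lower, beyond the scatter of compound 2.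

Compound 4 `Nc1ccc(CNc2ncnc3c2nnn3Cc2ccccc2Cl)cc1` differs from compound 2 in one place: 4-aminophenyl in place of cyclohexyl on a saturated chain carbon bound to a nitrogen on an aromatic ring.

Going by the values given here, two measured steps bear on this. The step of a 1.5-fold higher number from compound 1 to compound 2 (0.18 log units; within the scatter) shows that the chloro on the aromatic carbon, which compound 4 keeps, does not by itself move the number beyond the scatter. The step of a 6.0-fold lower number from compound 1 to compound 3 (0.78 log units; beyond the scatter) is the only one that touches the cyclohexylmethyl arm, and it was modest; it exchanged that arm for an aromatic group set directly on the ring nitrogen, whereas compound 4 keeps the chain carbon and adds 4-aminophenyl on it. Among the compounds with values here, no measured pair reports a 4-aminophenyl or a saturated-to-aromatic swap at this exact place, so the direction is uncertain.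

On balance a modest lowering is expected for compound 4, roughly a 1.9-fold lower number from compound 2 to compound 4 (0.29 log units; within the scatter), with a wide band. The estimate for compound 4 in this assay is 2200 nM, between 600 nM and 8000 nM.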

Compound 4, inhibition constant: > 1000 nM
Compound 4 gave a limit, no number; the forecaster's own chance of this, stated with the estimate: 5%; the middle value lies beyond the limit too.
By their numbers in this assay, from the lowest: compound 3; then compounds 1 and 2 (each within the scatter of the next).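

In this assay compound 4 gives > 1000 nM, a limit of the assay and not a number. The step from compound 2 to compound 4 therefore cannot be read, and no new step follows, because only that limit stands for compound 4: the limit of > 1000 nM in this assay, at which 1 of the 4 values shown sits.

The compounds shown leave open how far, and in which direction, 4-aminophenyl in place of cyclohexyl moves the number.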